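Thiophen-2-yl for thiophen-3-yl: compound 3 expectation

The source may report more compounds than this note shows. Statements on the series, on what has been measured and on what is new or still open speak of the compounds shown alone.

Measured so far in a functional assay on 786-0 cells (Homo sapiens) for inhibition, read by sulforhodamine B assay, with a stated time of 48 h, tested at 10 uM; a lower number here means less inhibition, a higher number more inhibition at the concentration tested (going by the name of the read-out):
Compound 1 `O=Cc1ccc(-c2cn3ccnc3c(-c3ccc4ncn(C5CCCCC5)c4c3)n2)cc1`: 46.7%
Compound 2 `c1cn2cc(-c3ccsc3)nc(-c3ccc4ncn(C5CCCCC5)c4c3)c2n1`: 6.35%

Compound 2 gives the lower of the two numbers; the step of a number 40.4 percentage points lower from compound 1 to compound 2 (beyond the scatter) sets it well apart from compound 1. Compound 3 `c1csc(-c2cn3ccnc3c(-c3ccc4ncn(C5CCCCC5)c4c3)n2)c1` differs from compound 2 by thiophen-2-yl in place of thiophen-3-yl on an aromatic carbon. Going by the values given here, no measured step matches a swap of this kind: the only step in hand exchanges a thiophen-3-yl for a 4-formylphenyl and is large, which says nothing about moving the same thiophene to its other ring carbon. The expected step of a number 3.7 percentage points higher from compound 2 to compound 3 (within the scatter) is therefore none beyond the scatter, and compound 3 is estimated at 10%, with a range of 0% to 35%.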

Compound 3, a percentage reported as inhibition, at one concentration (the size of the read-out at that concentration, not a potency): 4.1%
For compound 3 the middle estimate is 5.9 percentage points above the measured one; measured number inside the range.
By their numbers in this assay, from the lowest: compounds 3 and 2 (each within the scatter of the next); then compound 1.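

Thiophen-2-yl and thiophen-3-yl are not separated at this aromatic carbon in this assay, with a number 2.3 percentage points lower from compound 2 to compound 3 (within the scatter), so the point of attachment of the thiophene carries no readable difference here. The gap to the 4-formylphenyl group holds for both thiophenes, with a number 42.6 percentage points lower from compound 1 to compound 3 (beyond the scatter), a second large step of the same direction. Nothing at hand accounts for this gap.

Still open, on these data alone, is whether the phenyl ring or its formyl group goes with the higher number. An unsubstituted phenyl, or a phenyl bearing a carboxylic acid or an aminomethyl group, at this carbon would separate the two.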